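The source may report more compounds than this note shows. Statements on the series, on what has been measured and on what is new or still open speak of the compounds shown alone.

Compound 1 `CNC(=O)N1CCCc2ccc(NC(=O)c3cccc(-c4ccccc4)c3)cc21` is the reference point of this series. For the measured compounds named here, in a functional assay on MV4-11 cells (Homo sapiens) for antiproliferative activity, with a stated time of 6 days, tested at 1.56 uM (a higher number here means a stronger effect of the compound at the concentration tested, a lower number a weaker effect), compound 1 gives 2.83%, the lowest of the three numbers so far. Compound 3 `CNC(=O)N1CCCc2ccc(NC(=O)c3ccc(-c4cnn(S(C)(=O)=O)c4)cc3)cc21` stands nearest, giving 4.5% in this assay, a difference that lies within the scatter, while compound 2 `CNC(=O)N1CCCc2ccc(NC(=O)c3ccc(-c4ccncc4)cc3)cc21` stands furthest, giving 37.6% in this assay.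

Going by the values given here, the one measured step, a number 33.1 percentage points lower from compound 2 to compound 3 (beyond the scatter), shows that swapping one heteroaromatic ring for another on the same aromatic carbon can shift the read-out strongly downward. It does not concern the position changed here, so it gives only an indirect guide.

Compound 4 `CNC(=O)N1CCCc2ccc(NC(=O)c3cccc(-c4cc[nH]n4)c3)cc21` differs from compound 1 by a single exchange: 1H-pyrazol-3-yl in place of phenyl on an aromatic carbon. The change sits meta to a large group on the ring of the shared core. Among the compounds with values here, no measured pair shows this exact exchange, and the attachment position differs from that of compound 2 and compound 3, so any expectation carries wide uncertainty. Because compound 1 gives 2.83%, there is little room for the number to fall, and a modest rise is the more likely outcome, expected as a number 9.2 percentage points higher from compound 1 to compound 4 (within the scatter). In this assay compound 4 is therefore estimated at 12%, with a range from 0% to 35%.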

Compound 4, a percentage reported as inhibition, at one concentration (the size of the read-out at that concentration, not a potency): 27.3%
Compound 4: the middle estimate sits 15.3 percentage points below what was measured; the measured number falls inside the stated range.
By their numbers in this assay, from the lowest: compounds 1 and 3 (each within the scatter of the next); then compound 4; then compound 2.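

In this assay, the exchange of phenyl for 1H-pyrazol-3-yl comes with a number 24.5 percentage points higher from compound 1 to compound 4 (beyond the scatter), so this place, on an aromatic carbon meta to a large group, clearly responds to the ring it carries. The earlier step, a number 33.1 percentage points lower from compound 2 to compound 3 (beyond the scatter), concerned another place and another pair of rings and ran downward, whereas this is the only step shown that runs upward. The exchange puts a five-membered aromatic ring with 2 hetero atoms in place of a six-membered aromatic ring of carbon only and adds 1 hydrogen-bond donor and 1 hydrogen-bond acceptor, but this single pair cannot separate these differences, and no measurement at hand gives a cause for the rise.

The compounds shown leave open whether the rise belongs to the 1H-pyrazol-3-yl ring alone or would also come with another group at this place, such as an imidazol-4-yl ring, a carboxylic acid or an amine. They also leave open whether a read-out at one concentration would carry over to a measured potency.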